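Swapping the Hydroxypyridine for an Aminofluoropyridine

A few compounds are considered here, and "the series" means these few. Any claim that something is new, unique, unknown or untested is made for them only; others in the source may bear on it.

Two measured compounds share one core and differ only in the aryl group attached to it. In an in vitro assay on HEK385-7 cells for displacement of a labelled ligand from prostaglandin D2 receptor 2 (Homo sapiens) (on this read-out higher numbers stand for weaker inhibition and lower numbers for stronger inhibition), compound 1 `O=C(O)Cc1sc(C(c2ccc(F)cc2)c2ccc(F)cc2)nc1-c1cc(F)nc(F)c1` gives 5.4 nM. In this assay, among the compounds with values here, compound 2 `O=C(O)Cc1sc(C(c2ccc(F)cc2)c2ccc(F)cc2)nc1-c1ccnc(O)c1` gives 68 nM, the higher of the two numbers, and the only measured step, a 13-fold higher number from compound 1 to compound 2 (1.10 log units; beyond the scatter), separates it from compound 1. Compound 3 `Nc1cc(-c2nc(C(c3ccc(F)cc3)c3ccc(F)cc3)sc2CC(=O)O)cc(F)n1` carries the change (2-amino-6-fluoropyridin-4-yl in place of 2-hydroxypyridin-4-yl on an aromatic carbon). Within the data shown here, this change brings back one fluorine found in compound 1 and trades the hydroxy for an amino group, so the single step bearing on it, a 13-fold higher number from compound 1 to compound 2 (1.10 log units; beyond the scatter), suggests that part of the strength lost on going to compound 2 should return. The number for compound 3 is therefore expected to lie inside the span of the two measured values, with a step of a 4.5-fold lower number from compound 2 to compound 3 (0.66 log units; beyond the scatter) expected. Compound 3 is estimated at 15 nM, in the range 4 nM to 55 nM.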

Compound 3, half-maximal inhibitory concentration: 220 nM
The estimate for compound 3 lay 15-fold (1.17 log units) below the measured number; the measured number lies above the stated range.
By their numbers in this assay, from the lowest: compound 1; then compound 2; then compound 3.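

On the shared core, keeping one fluoro of the 2,6-difluoropyridin-4-yl group and replacing the other with amino costs a great deal of strength (a 41-fold higher number from compound 1 to compound 3 (1.61 log units; beyond the scatter)). The result also shows that bringing back a fluoro does not by itself recover strength, since the 2-amino-6-fluoropyridin-4-yl group falls short of even the 2-hydroxypyridin-4-yl group it replaces (a 3.2-fold higher number from compound 2 to compound 3 (0.51 log units; beyond the scatter)). Nothing available explains why this group fares so poorly here.

The step between the hydroxy and amino-fluoro groups changes two features at once, so the separate contributions of the amino and the fluoro remain unresolved. A 2-aminopyridin-4-yl group without the fluoro, or a 2-fluoropyridin-4-yl group with no amino, would help pull those contributions apart.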